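Removing the Hydroxyl: From Compound 2 to Compound 3

The compounds below may be only part of what the source reports. "The series", "measured", "known", "first", "only" and "open" are said of these compounds alone.

Of the compounds shown here, two sharing one core have been measured in an assay on cells for inhibition of interleukin-5 receptor subunit alpha (Mus musculus), read by WST assay, with a stated time of 48 h, tested at 30 uM, in the presence of a further agent that is not named here; a higher number here means more inhibition at the concentration tested (going by the name of the read-out), a lower number less inhibition. Compound 1 `CC(C)(CO)NCc1nc2c(OCC3CCCCC3)cccc2[nH]1` gives 54.7%. Among the measured compounds shown here, compound 2 `OCC(NCc1nc2c(OCC3CCCCC3)cccc2[nH]1)c1ccccc1` gives 77.7%, the higher of the two numbers, and the only step, a number 23 percentage points higher from compound 1 to compound 2 (beyond the scatter), stands beyond the scatter. Compound 3 `COc1ccc(CNCc2nc3c(OCC4CCCCC4)cccc3[nH]2)cc1` has not yet been measured. It differs from compound 2 in one place: 4-methoxybenzyl in place of 2-hydroxy-1-phenylethyl on an amine nitrogen. For the measured compounds named here, no measured step bears directly on this change, since the step from compound 1 to compound 2 kept the hydroxyl group on the amine substituent while varying the rest, whereas here the hydroxyl group leaves and a methoxy-bearing aromatic ring enters. The expectation therefore rests on little; a step of a number 17.7 percentage points lower from compound 2 to compound 3 (beyond the scatter) downward is expected, with wide uncertainty. Compound 3 is estimated at 60%, within a range from 35% to 85%.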

Compound 3, a percentage reported as inhibition, at one concentration (the size of the read-out at that concentration, not a potency): 43.3%
Compound 3: middle estimate off by 16.7 percentage points, on the high side; the measured number falls inside the stated range.
By their numbers in this assay, from the lowest: compound 3; then compound 1; then compound 2.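

In this assay, the exchange of 2-hydroxy-1-phenylethyl for 4-methoxybenzyl on the amine nitrogen, which keeps the same atoms joined differently, gives a number 34.4 percentage points lower from compound 2 to compound 3 (beyond the scatter). Placing the same group against the 1-(hydroxymethyl)-1-methylethyl substituent gives a number 11.4 percentage points lower from compound 1 to compound 3 (beyond the scatter), so among these three compounds the substituent without a hydrogen-bond donor gives the lowest number, which the earlier pair, both bearing a hydroxyl group, could not show. No measurement here explains the drop.

The compounds shown leave open whether the lower number follows the loss of the hydroxyl group, the arrival of the methoxy group, or the changed attachment of the aromatic ring. An unsubstituted benzyl or a 2-methoxy-1-phenylethyl group on this nitrogen would help separate these changes.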